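The source may report more compounds than this note shows. Statements on the series, on what has been measured and on what is new or still open speak of the compounds shown alone.

Compound 3 `CN1Cc2ccc(OCc3cccnc3)cc2[C@@H](O)C1` stands only at a limit in an ADME assay on Vero cells (Chlorocebus sabaeus) for cytotoxicity, read by sulforhodamine B assay, with a stated time of 72 h; on this read-out lower numbers stand for stronger inhibition and higher numbers for weaker inhibition: compound 3 gives > 50000 nM, which is a limit of the assay and not a number. Compound 1 `CN1Cc2ccc(OCc3ccccc3)cc2[C@@H](O)C1` likewise gives > 100000 nM, a limit. Compound 2 `CN1Cc2ccc(OCCC3CCCCC3)cc2[C@@H](O)C1` gives > 50000 nM, again a limit. The measured steps a step that the two limits leave unreadable from compound 1 to compound 2, a step that the two limits leave unreadable from compound 1 to compound 3 and a step that the two limits leave unreadable from compound 2 to compound 3 cannot be sized because the values sit at the limit of > 100000 nM in this assay, at which 1 of the 3 values shown sits, and (the limit of > 50000 nM in this assay, at which 2 of the 3 values shown sit).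

Compound 4 `CN1Cc2ccc(OCC3CCNCC3)cc2[C@@H](O)C1` differs from compound 3 by piperidin-4-yl in place of pyridin-3-yl on a saturated chain carbon bound to an oxygen on an aromatic ring. Going by the values given here, none of the measured steps gives a readable size for this change, so no step beyond the scatter is expected in this assay. Compound 4 is therefore estimated at 100000 nM, with a range of 30000 nM to 300000 nM, and the expected step is a step that the limit leaves unreadable from compound 3 to compound 4.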

Compound 4, half-maximal inhibitory concentration: > 100000 nM
Compound 4 gave a limit, no number; the forecaster's own chance of this, stated with the estimate: 90%; the middle value lies on the limit itself.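

In this assay compound 4 gives > 100000 nM, a limit and not a number, so its steps from compound 1, compound 2 and compound 3 cannot be read: the limit of > 100000 nM in this assay, at which 2 of the 4 values shown sit.

The compounds shown leave open whether any group on the saturated chain carbon bound to an oxygen on an aromatic ring gives a readable value in this assay.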